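The source may report more compounds than this note shows. Statements on the series, on what has been measured and on what is new or still open speak of the compounds shown alone.

Compound 1 `CC(C)CN1C(=O)/C(=C/c2ccc([N+](=O)[O-])cc2)S/C1=N\c1ccccc1`: > 100000 nM
Compound 2 `Cc1ccc(/C=C2\S/C(=N\c3ccccc3)N(CC(C)C)C2=O)cc1`: "not determined" (no result reported)

In an ADME assay on HepG2 cells (Homo sapiens) for cytotoxicity, read by MTT assay, with a stated time of 48 h (on this read-out higher numbers stand for weaker inhibition and lower numbers for stronger inhibition), compound 1 gives > 100000 nM. This entry is a limit of the assay and not a number. Compound 1 therefore stands at the limit of > 100000 nM in this assay, at which 1 of the 2 values shown sits. Compound 2 has the entry "not determined" (no result reported), so it offers no number for comparison.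

The next compound to be tested is compound 3 `CC(C)CN1C(=O)/C(=C/c2cccc(Cl)c2)S/C1=N\c1ccccc1`. It keeps the core of compound 1 and carries 3-chlorophenyl in place of 4-nitrophenyl on a double-bonded chain carbon bound to a double-bonded ring carbon.

Within the data shown here, no pair of measured compounds shows how far a change like this can move the result, so the expectation has only one anchor. In this assay no step beyond the usual scatter is expected. Compound 1 holds only a limit at > 100000 nM. The step of an at least 1.1-fold lower number from compound 1 to compound 3 (0.04 log units; that floor lies within the scatter) is expected to be small. The assay may well report only a limit again. If a number is reported, compound 3 is estimated at 90000 nM, with an expected range from 30000 nM to 200000 nM.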

Compound 3, half-maximal inhibitory concentration: 88100 nM
For compound 3 the middle estimate is 1.0-fold (0.01 log units) above the measured one; the range from low to high includes it.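

Compound 3 brings the first true number into this assay, so this position on the shared core now has a measured reading to work from. The entry for compound 1 is only a limit: the limit of > 100000 nM in this assay, at which 1 of the 3 values shown sits. Placing 3-chlorophenyl where 4-nitrophenyl stood, on a double-bonded chain carbon bound to a double-bonded ring carbon, gives an at least 1.1-fold lower number from compound 1 to compound 3 (0.05 log units; that floor lies within the scatter), so the two compounds can only be said to differ by an amount that starts at this floor, and the real step could be small or considerably larger.

The two groups differ in both the atoms they carry and the number in their names, so the compounds shown leave open whether the chlorine, the nitro group or the ring position matters here, and 4-chlorophenyl would be the group that separates these. Also open, as far as these compounds go, is how a phenyl ring bearing an amine or a carboxylic acid would read at this place, and compound 2 offers no number to help.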